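Cyclopentyl amide replacing chloroamide in the anilide series

This account rests on a few compounds, and the source may have more. Where it says the series, first, only, none or still open, it means among the compounds named here.

For the measured compounds named here, compound 2 `COc1ccc(C(=O)Nc2ccccc2)cc1NC(=O)C(C)Cl` is the only member of this set with a number in an ADME assay on MDCK cells (Canis lupus familiaris) for cytotoxicity, read by cytopathic effect, with a stated time of 48 h; on this read-out higher numbers stand for lower toxicity in this test and lower numbers for higher toxicity in this test; in that test compound 2 gives 200 uM. The other measured member, compound 1 `CCC(=O)Nc1cc(C(=O)NC2CCC2)ccc1OC`, gives only a limit of > 724 uM in this assay, not a number. The line of interest runs from compound 2 to compound 3 `COc1ccc(C(=O)Nc2ccccc2)cc1NC(=O)C1CCCC1`, which has not yet been tested. The change is cyclopentyl in place of 1-chloroethyl on a carbonyl carbon. Going by the values given here, no measured step of this kind exists in the set, so the direction can only be projected from the two values shown. The step from compound 2 to compound 3 is expected to be a 2.5-fold higher number from compound 2 to compound 3 (0.40 log units; beyond the scatter), towards lower toxicity, and larger than the scatter. For compound 3 the estimated half-maximal toxic concentration is 500 uM, with a range from 200 uM to 1000 uM. The upper end of that range is set with the limit of > 724 uM in this assay, at which 1 of the 2 values shown sits, in mind, so a limit rather than a number is a real possibility for compound 3.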

Compound 3, half-maximal toxic concentration: 459 uM
Compound 3: the middle estimate sits 1.1-fold (0.04 log units) above what was measured; the measured number falls inside the stated range.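

In this assay, for the compounds shown here, the first measured step at this place is cyclopentyl in place of 1-chloroethyl on a carbonyl carbon, which gives a 2.3-fold higher number from compound 2 to compound 3 (0.36 log units; beyond the scatter), a modest move towards lower toxicity in this test. A change at this carbonyl carbon alone, with the rest of compound 2 held, therefore moves the read-out beyond the scatter. Going by these compounds alone, the single step removes the chlorine and brings in the ring together, so it does not separate these two parts of the change.

From the compounds shown here alone, how a cyclohexyl or a 1-aminoethyl group on the same carbonyl carbon would read remains open. Compound 1 differs from compound 2 in more than one place and offers no step here, and its entry is a limit and not a number: the limit of > 724 uM in this assay, at which 1 of the 3 values shown sits.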